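A few compounds are considered here, and "the series" means these few. Any claim that something is new, unique, unknown or untested is made for them only; others in the source may bear on it.

Measured so far in a functional assay on BT-549 cells (Homo sapiens) for inhibition, read by sulforhodamine B assay, with a stated time of 48 h; on this read-out higher numbers stand for weaker inhibition of growth and lower numbers for stronger inhibition of growth:

Compound 1 `COc1cc(-c2cc(/C=C/C(=O)c3ccc(N)cc3)[nH]n2)cc(OC)c1OC`: compound 1 gives 1380 nM.
Compound 2 `COc1cc(-c2cc(/C=C/C(=O)c3ccc(Cl)c(Cl)c3)[nH]n2)cc(OC)c1OC`: compound 2 gives 8400 nM.

Going by the values given here, compound 1 holds the lowest of the two numbers; the only other number stands off by a 6.1-fold higher number from compound 1 to compound 2 (0.78 log units; beyond the scatter), so on what is known compound 1 is the stronger grower-inhibitor of the pair.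

Compound 3 `COc1cc(-c2cc(/C=C/C(=O)c3ccc(F)c(F)c3)[nH]n2)cc(OC)c1OC` differs from compound 1 by 3,4-difluorophenyl in place of 4-aminophenyl on a carbonyl carbon. Among the compounds with values here, the one measured step that bears on this is a 6.1-fold higher number from compound 1 to compound 2 (0.78 log units; beyond the scatter), where a dihalogenated phenyl likewise replaced the 4-aminophenyl on the carbonyl carbon; that step was modest but clearly beyond the scatter. Compound 3 carries the lighter halogen pair, so the same direction is expected, a weakening of growth inhibition, with the size uncertain and possibly somewhat smaller. For compound 3 the expected step is a 3.6-fold higher number from compound 1 to compound 3 (0.56 log units; beyond the scatter), giving an estimate of 5000 nM with a range from 1800 nM to 14000 nM.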

Compound 3, concentration for 50% growth inhibition: 4110 nM
The estimate for compound 3 lay 1.2-fold (0.09 log units) above the measured number; the range from low to high includes it.
By their numbers in this assay, from the lowest: compound 1; then compound 3; then compound 2.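

In this assay the step of a 3.0-fold higher number from compound 1 to compound 3 (0.47 log units; beyond the scatter) shows that 3,4-difluorophenyl on the carbonyl carbon also gives weaker growth inhibition than 4-aminophenyl, so this loss is not confined to 3,4-dichlorophenyl. The identity of the halogen pair also matters at this position: the step of a 2.0-fold lower number from compound 2 to compound 3 (0.31 log units; beyond the scatter) separates the two dihalogenated phenyl groups, although neither of them matches compound 1 in this read-out. No available measurement accounts for these differences.

The compounds shown leave open whether the lead of compound 1 depends on the amine itself or would persist with a hydroxyl or dimethylamino group on the phenyl ring. They also leave open how a phenyl ring carrying a single fluorine or chlorine, or an unsubstituted phenyl, would compare.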